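Swapping an Ether Tail for an Amide

The compounds below may be only part of what the source reports. "The series", "measured", "known", "first", "only" and "open" are said of these compounds alone.

Compound 3 `COCC[C@@H]1C[C@@H](c2ccc(Cl)c(Cl)c2)[C@H](NC(=O)c2cc(-c3c(Cl)cnn3C)c(Cl)o2)CN1` gives 250 nM in a functional assay on LNCaP cells (Homo sapiens) for antiproliferative activity (a lower number here means a stronger inhibitor, a higher number a weaker inhibitor), the lowest number among the three measured compounds; compound 1 `Cn1ncc(Cl)c1-c1cc(C(=O)N[C@@H]2CN[C@H](CC(=O)O)C[C@H]2c2ccc(Cl)c(Cl)c2)oc1Cl` gives 640 nM and compound 2 `Cn1ncc(Cl)c1-c1cc(C(=O)N[C@@H]2CN[C@H](CCN3CCCC3)C[C@H]2c2ccc(Cl)c(Cl)c2)oc1Cl` gives 1920 nM. Compound 4 `Cn1ncc(Cl)c1-c1cc(C(=O)N[C@@H]2CN[C@H](CC(N)=O)C[C@H]2c2ccc(Cl)c(Cl)c2)oc1Cl` differs from compound 3 by carbamoyl in place of methoxymethyl on a saturated chain carbon bound to a saturated ring carbon. The comparison that bears most on this is a 2.6-fold lower number from compound 1 to compound 3 (0.41 log units; beyond the scatter), where carboxy, a group that like carbamoyl carries a carbonyl, gave way to methoxymethyl. The step of a 3.0-fold higher number from compound 1 to compound 2 (0.48 log units; beyond the scatter) shows that another change at this same place also weakened the effect. A modest rise in the number is expected, a 2.0-fold higher number from compound 3 to compound 4 (0.30 log units; within the scatter), placing compound 4 somewhere between compound 1 and compound 3. The estimate for compound 4 in this assay is 500 nM, within a range of 200 nM to 1300 nM.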

Compound 4, half-maximal inhibitory concentration: 160 nM
Compound 4: middle estimate off by 3.1-fold (0.49 log units), on the high side, and the stated range ends above it.
By their numbers in this assay, from the lowest: compounds 4 and 3 (each within the scatter of the next); then compound 1; then compound 2.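

In this assay, carbamoyl and methoxymethyl are not separated at this position, with a 1.6-fold lower number from compound 3 to compound 4 (0.19 log units; within the scatter). The position is still sensitive to small edits: amino for hydroxy on the carbonyl carbon gives a 4.0-fold lower number from compound 1 to compound 4 (0.60 log units; beyond the scatter), and carbamoyl for (pyrrolidin-1-yl)methyl gives a 12-fold lower number from compound 2 to compound 4 (1.08 log units; beyond the scatter). No measurement here explains why these changes shift the number. Going by these compounds, it remains open whether an N-methyl amide or a nitrile on this saturated chain carbon would stay with compound 3 and compound 4, or drift towards compound 1 or compound 2.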